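This account rests on a few compounds, and the source may have more. Where it says the series, first, only, none or still open, it means among the compounds named here.

Working notes on a small set of analogues sharing one core. Compound 1 `Nc1nc(NCc2ccccc2)nc(-c2cc(Cl)ccc2CO)n1` has been measured in a functional assay on cells for positive allosteric modulation of G-protein coupled receptor 68 (Homo sapiens), read by a luciferase reporter and cAMP accumulation, with a stated time of 30 min, at pH 6.8 and pH 8.3, in the presence of a further agent that is not named here (a lower number here means a less potent compound, a higher number a more potent compound, by a factor of ten per unit of this negative logarithm), where compound 1 gives 4.49. Compound 2 `COc1ccc(-c2nc(N)nc(NCc3ccccc3)n2)c(CO)c1` in this assay gives 4.12. Compound 3 `Nc1nc(NCc2ccc(F)cc2)nc(-c2ccccc2CO)n1` in this assay gives 3.97.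

On the three numbers in hand, compound 3 stands lowest. The value of compound 2 lies within the scatter of that of compound 3, so no order can be read between these two. Compound 1 is higher than compound 3 by an amount beyond the scatter, and that is the only gap in the set that stands out.

Compound 4 `COc1ccc(CNc2nc(N)nc(-c3ccccc3CO)n2)cc1` has not yet been measured. Against compound 3 it differs by methoxy in place of fluoro on an aromatic carbon. For the measured compounds named here, no measured pair in the set isolates this single exchange, so there is no step to lean on; the two values of compound 2 and compound 3 sit within the scatter of each other and say nothing about it. The step expected here is a number 0.13 log units higher from compound 3 to compound 4 (within the scatter), that is, nothing beyond the scatter in either direction. For compound 4 the estimate in this assay is 4.1, with a range from 3.6 to 4.6.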

Compound 4, negative logarithm of the antagonist equilibrium constant: 3.34
Estimate against measurement, compound 4: 0.76 log units above, and the stated range ends above it.
By their numbers in this assay, from the lowest: compound 4; then compounds 3 and 2 (each within the scatter of the next); then compound 1.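

In this assay, for the compounds shown here, the exchange of fluoro for methoxy, on an aromatic carbon para to a large group, gives a number 0.63 log units lower from compound 3 to compound 4 (beyond the scatter) and is the only step in the set between compounds that differ in one place. Going by these compounds alone, this position is therefore not indifferent to what it carries: of the two groups seen here, fluoro goes with the higher number, something the earlier compounds could not show, as no two of them differed in one place only. No measurement in hand bears on why the number falls with this exchange.

Going by these compounds, a single step between two groups fixes no trend, so it remains open whether the 4-methoxyphenyl result reflects something particular to methoxy or would be shared by other groups in this place. On these data alone, whether a nitrile, a dimethylamino group, a carboxylic acid or a longer chain such as ethoxy would stay near fluoro or fall with methoxy is unknown, as is whether the same exchange would give a step of this size alongside the other substituents of compound 1 and compound 2.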